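The compounds below may be only part of what the source reports. "The series", "measured", "known", "first", "only" and "open" are said of these compounds alone.

Compound 3 `CCCOC(=O)[C@@H](N)CCC(=O)NCCSC(=O)C(C)(C)C` stands in an ADME assay on isolated protein for metabolic stability, with Cocaine esterase (Homo sapiens) as the target (a lower number here means that the compound disappears faster, a higher number that the compound lasts longer), at 0.167 h, level with compound 1 `CCOC(=O)[C@@H](N)CCC(=O)NCCSC(=O)c1ccccc1`, which gives 0.167 h, and with compound 2 `CCCOC(=O)[C@@H](N)CCC(=O)NCCSC(C)=O`, which gives 0.167 h. Within the data shown here, the single measured step at the same place, no change at the digits printed from compound 2 to compound 3 (within the scatter), put tert-butyl in place of methyl on a carbonyl carbon and left the half-life unchanged. Compound 4 `CCCOC(=O)[C@@H](N)CCC(=O)NCCSC(=O)c1ccccc1` differs from compound 3 in one place: phenyl in place of tert-butyl on a carbonyl carbon. That earlier step was flat, and compound 1, which already carries the phenyl on the carbonyl carbon, shows the same value as compound 3, so nothing points to movement. Compound 4 is therefore expected to show no step beyond the scatter, no change at the digits printed from compound 3 to compound 4 (within the scatter), with an estimated value of 0.167 h between 0.1 h and 0.35 h.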

Compound 4, half-life: 0.167 h
The estimate for compound 4 equals the measured number at the digits printed, and the stated range covers the measured number.
By their numbers in this assay, from the lowest: compounds 1, 2, 3 and 4 (each within the scatter of the next).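

Phenyl on the carbonyl carbon, the first ring tested at this position of the propyl series, behaves like the smaller groups in half-life: no change at the digits printed from compound 3 to compound 4 (within the scatter) and no change at the digits printed from compound 2 to compound 4 (within the scatter) on the same series. The other place also stays flat, as methyl in place of hydrogen on a saturated chain carbon gives no change at the digits printed from compound 1 to compound 4 (within the scatter) in the thioester series. From the compounds shown here alone, whether an amine or a carboxylic acid on the carbonyl carbon, or a longer chain at the saturated carbon, would shift the half-life remains open. No measurement shown here explains the identical values.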